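The source may report more compounds than this note shows. Statements on the series, on what has been measured and on what is new or still open speak of the compounds shown alone.

Compound 1, `CCn1ncnc1-c1ccccc1NCC1=NCCN1`, compound 2, `CCCn1ncnc1-c1ccccc1NCC1=NCCN1`, and compound 3, `CCCCn1ncnc1-c1ccccc1NCC1=NCCN1`, share one core and differ only in the chain on the aromatic nitrogen. In an in vitro functional assay on cells (Fibroblast) for agonist activity at Alpha-1B adrenergic receptor (Homo sapiens) (on this read-out higher numbers stand for an effect only at larger amounts of compound and lower numbers for an effect already at smaller amounts), compound 1 gives 63.1 nM, compound 2 gives 316 nM, and compound 3 gives 200 nM. Compound 3 thus stands second highest of the three numbers, close to compound 2 and clearly apart from compound 1.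

Compound 4, `CC(C)n1ncnc1-c1ccccc1NCC1=NCCN1`, is reached from compound 3 by the change (isopropyl in place of butyl on an aromatic nitrogen). The measured steps that bear on this are a 5.0-fold higher number from compound 1 to compound 2 (0.70 log units; beyond the scatter), a 3.2-fold higher number from compound 1 to compound 3 (0.50 log units; beyond the scatter) and a 1.6-fold lower number from compound 2 to compound 3 (0.20 log units; within the scatter). Lengthening the chain from ethyl to propyl or butyl raised the number, while going from propyl to butyl changed it within the scatter only. Isopropyl has as many carbons as propyl but is branched, and no measured pair shows what branching does. On this basis the number for compound 4 is expected near that of compound 3, with an estimated step of a 1.3-fold lower number from compound 3 to compound 4 (0.10 log units; within the scatter), within the scatter. Compound 4 is therefore estimated at 160 nM, in a range from 60 nM to 400 nM.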

Compound 4, half-maximal effective concentration: < 100000 nM
Compound 4 was reported as a limit; the forecaster's own chance of this, stated with the estimate: 2%; the middle value is on the limit's open side.
By their numbers in this assay, from the lowest: compound 1; then compounds 3 and 2 (each within the scatter of the next).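

In this assay compound 4 gives < 100000 nM, which is a limit and not a number. Going by these compounds alone, no step from compound 1, compound 2 or compound 3 to compound 4 can be read, because of this: the limit of < 100000 nM in this assay, at which 1 of the 4 values shown sits. The compounds shown leave open how the branched isopropyl compares with the straight chains.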